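A few compounds are considered here, and "the series" means these few. Any claim that something is new, unique, unknown or untested is made for them only; others in the source may bear on it.

Going by the values given here, in a functional assay on DU-145 cells (Homo sapiens) for cytotoxicity, read by trypan blue exclusion, with a stated time of 96 h (a lower number here means a stronger inhibitor, a higher number a weaker inhibitor), compound 3 (`COc1cc(OC)c(/C=C/S(=O)(=O)Nc2ccc(OC)c(F)c2)c(OC)c1`) gives 200 nM, the lowest of the three numbers so far. Compound 1 (`COc1cc(OC)c(/C=C/S(=O)(=O)Nc2ccc(F)c(N)c2)c(OC)c1`) gives 10000 nM, and compound 2 (`COc1ccc(NS(=O)(=O)/C=C/c2c(F)c(F)c(F)c(F)c2F)cc1N`) gives 75000 nM. Compound 4 (`COC(=O)C(C)Nc1cc(NS(=O)(=O)/C=C/c2c(OC)cc(OC)cc2OC)ccc1OC`) carries (1-(methoxycarbonyl)ethyl)amino in place of the fluoro of compound 3, on an aromatic carbon ortho to a methoxy group: (1-(methoxycarbonyl)ethyl)amino in place of fluoro on an aromatic carbon. Among the compounds with values here, the only measured step that bears on this change is the large 50-fold lower number from compound 1 to compound 3 (1.70 log units; beyond the scatter), which exchanges 3-amino-4-fluorophenyl for 3-fluoro-4-methoxyphenyl as a whole and so gives no direction for the new group. No step beyond the scatter is therefore expected in this assay, though the uncertainty is wide. The expected step, a 1.3-fold lower number from compound 3 to compound 4 (0.12 log units; within the scatter), is only an estimate. For compound 4 the estimated value is 150 nM, with an expected range of 20 nM to 1500 nM.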

Compound 4, half-maximal inhibitory concentration: 100 nM
Beside the measured number, compound 4's estimate is 1.5-fold (0.18 log units) above it; measured number inside the range.
By their numbers in this assay, from the lowest: compounds 4 and 3 (each within the scatter of the next); then compound 1; then compound 2.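

In this assay, (1-(methoxycarbonyl)ethyl)amino in place of fluoro gives a 2.0-fold lower number from compound 3 to compound 4 (0.30 log units; within the scatter). Going by these compounds alone, this is the first reading of this single change: on this aromatic carbon, ortho to a methoxy group, the much larger chain with its ester leaves the number within the scatter, whereas the earlier step exchanged the whole 3-amino-4-fluorophenyl group and could not isolate this position. The compounds shown leave open whether a carboxylic acid in place of the ester, or a longer chain, would be tolerated equally on this carbon. No measurement offered here explains why the number holds.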